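Clearance of compound 3 after ethyl to isopropyl

A few compounds are considered here, and "the series" means these few. Any claim that something is new, unique, unknown or untested is made for them only; others in the source may bear on it.

Measured so far in an ADME assay (liver) for metabolic stability, with Liver microsome (Homo sapiens) as the target, using microsomes; on this read-out lower numbers stand for slow clearance and higher numbers for fast clearance
- compound 1 `c1ccc(CNc2nnc(-c3c[nH]c4ncccc34)o2)cc1` at 31 mL.min-1.g-1
- compound 2 `CC[C@@H](Nc1nnc(-c2c[nH]c3ncccc23)o1)c1ccccc1` at 70 mL.min-1.g-1

In this assay compound 2 stands at 70 mL.min-1.g-1 and is the higher of the two numbers. Compound 3 `CC(C)[C@@H](Nc1nnc(-c2c[nH]c3ncccc23)o1)c1ccccc1` has not been measured. It differs from compound 2 by methyl in place of hydrogen on a saturated chain carbon bound to two saturated chain carbons with methyl in place of hydrogen on a saturated chain carbon bound to two saturated chain carbons, which reads as ethyl to isopropyl. Among the compounds with values here, only one measured step bears on this, a 2.3-fold higher number from compound 1 to compound 2 (0.35 log units; beyond the scatter) for ethyl in place of hydrogen at a different carbon. That step is modest and beyond the scatter, but it is a single precedent. The estimate means a 1.3-fold higher number from compound 2 to compound 3 (0.11 log units; within the scatter) as an expected upward move, smaller than that precedent and possibly within the scatter. For compound 3 the estimated value is 90 mL.min-1.g-1 with an expected range from 45 mL.min-1.g-1 to 170 mL.min-1.g-1 on measurement.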

Compound 3, intrinsic clearance in microsomes: 66 mL.min-1.g-1
Compound 3: middle estimate off by 1.4-fold (0.13 log units), on the high side; low and high end bracket the measured number.
By their numbers in this assay, from the lowest: compound 1; then compounds 3 and 2 (each within the scatter of the next).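

The ethyl to isopropyl change in this assay gives a 1.1-fold lower number from compound 2 to compound 3 (0.03 log units; within the scatter), so adding this methyl on a saturated chain carbon bound to two saturated chain carbons does not separate compound 3 from compound 2. Isopropyl in place of hydrogen on the saturated chain carbon bound to an aromatic carbon and a nitrogen on an aromatic ring gives a 2.1-fold higher number from compound 1 to compound 3 (0.33 log units; beyond the scatter), which, like a 2.3-fold higher number from compound 1 to compound 2 (0.35 log units; beyond the scatter), lies beyond the scatter, so with these two groups the separation from compound 1 persists whether the group is ethyl or isopropyl. Nothing available here accounts for these numbers.

Going by these compounds, whether a group of another kind at this carbon, such as an amine, a carboxylic acid or a longer chain, would stay with compound 2 and compound 3 or come closer to compound 1 at 31 mL.min-1.g-1 remains open. Also open, on these data alone, is whether the same change carries over with a fluorine on the phenyl ring.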